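Chain extension from compound 3 to compound 4

The source may report more compounds than this note shows. Statements on the series, on what has been measured and on what is new or still open speak of the compounds shown alone.

Measured so far in a functional assay on MCF7 cells (Homo sapiens) for antiproliferative activity, read by MTT assay, with a stated time of 48 h; a lower number here means a stronger inhibitor, a higher number a weaker inhibitor
- compound 1 `CCCCCCCn1cc(COC[C@@H]2OC[C@H](N)[C@@H]2O)nn1` with > 128000 nM as a limit of the assay
- compound 2 `CCCCCCCCCCn1cc(COC[C@@H]2OC[C@H](N)[C@@H]2O)nn1` with 9640 nM
- compound 3 `CCCCCCCCCCCCn1cc(COC[C@@H]2OC[C@H](N)[C@@H]2O)nn1` with 2210 nM

Compound 3 carries the lowest number of the three in this assay with compound 2 the nearest. The value of compound 1 is a limit of > 128000 nM in this assay, at which 1 of the 3 values shown sits, and no more.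

Compound 4 `CCCCCCCCCCCCCCCCCCn1cc(COC[C@@H]2OC[C@H](N)[C@@H]2O)nn1` differs from compound 3 only on the chain: hexyl in place of hydrogen on a saturated chain carbon, ten or more bonds along the chain from an aromatic nitrogen with the shared core unchanged. Among the measured compounds shown here, three measured steps bear on this change, all lengthening the same chain. The steps of an at least 13-fold lower number from compound 1 to compound 2 (1.12 log units; beyond the scatter) and an at least 57-fold lower number from compound 1 to compound 3 (1.76 log units; beyond the scatter) are large, though each starts from a limit. The step of a 4.4-fold lower number from compound 2 to compound 3 (0.64 log units; beyond the scatter) is modest, and it is the closest guide, as it alone sits at the same place on the chain as the change to compound 4.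

For the measured compounds named here, all three steps run towards lower numbers and no compound goes against this so far. Three compounds cannot show how far that trend carries, however, and hexyl is a larger addition than the ethyl of that last step. A further modest fall and a rise both remain possible, so no step beyond the scatter is expected in this assay and the range is kept wide. The expected change is a 1.1-fold lower number from compound 3 to compound 4 (0.04 log units; within the scatter) as an estimate. Compound 4 is expected at about 2000 nM with an estimated range from 500 nM to 15000 nM in this read-out.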

Compound 4, half-maximal inhibitory concentration: 7580 nM
Compound 4: middle estimate off by 3.8-fold (0.58 log units), on the low side; the range from low to high includes it.
By their numbers in this assay, from the lowest: compound 3; then compounds 4 and 2 (each within the scatter of the next). At a limit, above all of these: compound 1.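

In this assay, the fall in number seen as the chain lengthened does not carry on to compound 4: a 3.4-fold higher number from compound 3 to compound 4 (0.54 log units; beyond the scatter), so the earlier trend reverses at this position, and compound 3 keeps the lowest number of the four, with compound 4 going against the trend; the longer comparison, a 1.3-fold lower number from compound 2 to compound 4 (0.10 log units; within the scatter), shows that these two chains on either side of compound 3 cannot be told apart. The step from the shortest chain remains clear, an at least 16-fold lower number from compound 1 to compound 4 (1.22 log units; beyond the scatter), so the long chain of compound 4 still retains a gain over that of compound 1. The value of compound 1 is a limit, so this step gives only a minimum size: the limit of > 128000 nM in this assay, at which 1 of the 4 values shown sits.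

The compounds shown leave open where the turn lies between compound 3 and compound 4, which a tetradecyl or hexadecyl chain on the shared core would help to place. Going by these compounds, it also remains open whether a chain ending in a hydroxyl group or a carboxylic acid would follow the same course with length.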